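Swapping the Ester Side Group of Compound 2

The source may hold more compounds than are shown below. What is called first, only, known or untested is meant among the compounds shown, and "the series" means these compounds.

For the measured compounds named here, in a functional assay on MOLT-4 cells (Homo sapiens) (a lower number here means a stronger inhibitor, a higher number a weaker inhibitor), compound 2 (`CN(C)CC1CCC/C(=C\c2ccc(OC(=O)/C=C/c3ccc(F)cc3)cc2)C1=O`) gives 3780 nM and holds the lower of the two numbers so far, while compound 1 (`O=C(/C=C/c1ccc(F)cc1)Oc1ccc(/C=C2\CCCCC2=O)cc1`) gives 26600 nM on the same read-out. Going by the values given here, the only measured step is a 7.0-fold lower number from compound 1 to compound 2 (0.85 log units; beyond the scatter) for (dimethylamino)methyl in place of hydrogen on a saturated ring carbon, a modest change beyond the scatter. That group stays in compound 3 (`COc1ccc(C(=O)Oc2ccc(/C=C3\CCCC(CN(C)C)C3=O)cc2)cc1`), so this step says little about the new change. Compound 3 instead carries 4-methoxyphenyl in place of 2-(4-fluorophenyl)ethenyl on a carbonyl carbon. Among the compounds with values here, no measured step touches this place, and the data give neither a size nor a direction for it. In this assay the expected change is a 1.2-fold higher number from compound 2 to compound 3 (0.08 log units; within the scatter) and nothing beyond the scatter is anticipated. Compound 3 is estimated at 4500 nM with a wide expected range from 1500 nM to 14000 nM for now.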

Compound 3, half-maximal inhibitory concentration: 2360 nM
The estimate for compound 3 lay 1.9-fold (0.28 log units) above the measured number; the range from low to high includes it.
By their numbers in this assay, from the lowest: compounds 3 and 2 (each within the scatter of the next); then compound 1.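

In this assay the group on the carbonyl carbon could be exchanged without a difference that stands out from the scatter: the result is a 1.6-fold lower number from compound 2 to compound 3 (0.20 log units; within the scatter) for 4-methoxyphenyl in place of 2-(4-fluorophenyl)ethenyl. For the compounds shown here, this is the first reading at this place, and it shows that the double bond outside aromatic rings and the fluorine of the leaving group can both go, with a hydrogen-bond acceptor entering, while the number stays within the scatter. No measurement at hand accounts for this outcome.

The ethenyl link, the fluorine and the methoxy group change together in this one step, and their separate contributions remain unresolved. Also open, as far as these compounds go, is how an amine, a carboxylic acid or a longer chain on this carbonyl carbon would read in this assay.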